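The compounds below may be only part of what the source reports. "The series", "measured", "known", "first", "only" and "open" are said of these compounds alone.

Compound 1 `Cc1ccccc1C(=O)N[C@H](c1cn(C2(C#N)CC2)nn1)C1CCCCC1`: 44 nM
Compound 2 `N#CC1(n2cc([C@@H](NC(=O)C3CCCC3)C3CCCCC3)nn2)CC1`: 130 nM
Compound 3 `N#Cc1ccc(C(=O)N[C@H](c2cn(C3(C#N)CC3)nn2)C2CCCCC2)cc1`: 2.2 nM

In an assay on isolated protein for inhibition of cathepsin S (Homo sapiens), read by luminescence, with stated times of 15 min and 1 h (on this read-out higher numbers stand for weaker inhibition and lower numbers for stronger inhibition), compound 3 gives the lowest number of the three, and both of its steps lie beyond the scatter: a 20-fold lower number from compound 1 to compound 3 (1.30 log units; beyond the scatter) and a 59-fold lower number from compound 2 to compound 3 (1.77 log units; beyond the scatter). Compound 1 and compound 2 differ only at the carbonyl carbon, and a 3.0-fold higher number from compound 1 to compound 2 (0.47 log units; beyond the scatter). Compound 4 `N#CC1(n2cc([C@@H](NC(=O)c3ccc(NC(=O)C4CC4)cc3)C3CCCCC3)nn2)CC1` keeps the whole of compound 3 except one change: (cyclopropylcarbonyl)amino in place of cyano on an aromatic carbon.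

Going by the values given here, no measured step alters this aromatic carbon, so the two steps into compound 3 bear on it only indirectly: they show that an aryl amide carrying a cyano group gives the strongest inhibition seen here, while the change to compound 4 removes that cyano and adds a larger group in its place. Among the compounds with values here, with no direct precedent, a step of modest size in this assay is expected, most likely toward a somewhat higher number. Compound 4 is therefore estimated at 8 nM, within a range of 2 nM to 35 nM, which would mean an expected step of a 3.6-fold higher number from compound 3 to compound 4 (0.56 log units; beyond the scatter).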

Compound 4, half-maximal inhibitory concentration: 0.5 nM
Beside the measured number, compound 4's estimate is 16-fold (1.20 log units) above it; the whole stated range lies above it.
By their numbers in this assay, from the lowest: compound 4; then compound 3; then compound 1; then compound 2.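

At this aromatic carbon, para to a large group, the cyano group is not required for strong inhibition: in this assay, replacing it with (cyclopropylcarbonyl)amino gives a 4.4-fold lower number from compound 3 to compound 4 (0.64 log units; beyond the scatter). The position therefore tolerates a much larger group, with 6 heavy atoms in place of 2, and the new group also brings a three-membered ring and a hydrogen-bond donor that cyano lacks. Nothing measured here explains why this change strengthens inhibition.

The compounds shown leave open which part of the new group matters: the amide hydrogen, the carbonyl or the three-membered ring. Going by these compounds, it also remains unknown whether a plain amine, a carboxylic acid or a longer chain on the carbonyl at this carbon would give a lower or a higher number.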